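The source may report more compounds than this note shows. Statements on the series, on what has been measured and on what is new or still open speak of the compounds shown alone.

Working notes on the series. For the measured compounds named here, compound 1 `CCCCc1ccc2ncc(-c3nn[nH]n3)cc2c1` carries a butyl group on the shared core and is the one member with a plain number in a functional assay on the whole organism (strain Sprague-Dawley) for inhibition, with Rattus norvegicus as the target; on this read-out higher numbers stand for an effect only at larger amounts of compound and lower numbers for an effect already at smaller amounts: compound 1 gives 5 mg/kg. Compound 2 `FC(F)(F)c1ccc2cc(-c3nn[nH]n3)cnc2c1` carries a trifluoromethyl group in its place; in this assay compound 2 reaches only a limit of the assay, < 10 mg/kg, which is the limit of < 10 mg/kg in this assay, at which 1 of the 3 values shown sits. Compound 3 `COc1ccc2c(O)c(C(=O)O)cnc2c1` differs more widely, with a methoxy group, a hydroxyl and a carboxylic acid on its core; in this assay compound 3 also stops at a limit of the assay, > 50 mg/kg, which is the limit of > 50 mg/kg in this assay, at which 1 of the 3 values shown sits. Going by the values given here, no pair of measured compounds differs in a single place, so no measured step is available, and compound 1 stands as the single fixed point among the three, the other two values being limits.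

Compound 4 `c1nc2ccc(C3CCCCC3)cc2cc1-c1nn[nH]n1` has not yet been measured. It differs from compound 1 by one change: cyclohexyl in place of butyl on an aromatic carbon. Among the compounds with values here, no measured step bears on this exchange. The step of no change at the digits printed from compound 1 to compound 4 (within the scatter) is expected to stay within the scatter, with no direction beyond it. Compound 4 is therefore estimated at 5 mg/kg in this assay, with a range from 2 mg/kg to 15 mg/kg. A limit instead of a number remains possible.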

Compound 4, minimum effective dose: 5 mg/kg
For compound 4 middle estimate and measured number coincide at the digits printed; low and high end bracket the measured number.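

this assay now holds a first measured step at this position, no change at the digits printed from compound 1 to compound 4 (within the scatter), for cyclohexyl in place of butyl on an aromatic carbon of the shared core. The earlier compounds shown here, with no pair differing in one place, could not show that an open chain and a six-membered non-aromatic ring of carbon only, the larger of the two by heavy atoms, can be exchanged here with the read-out staying within the scatter. Nothing measured in the series bears on why these two groups read alike.

Still open, on these data alone, is how far this tolerance extends on the same aromatic carbon, as the two groups compared are both carbon only and carry no hydrogen-bond donors or acceptors, so that an amine, a carboxylic acid or a longer chain such as octyl in this place would each be a wider test of the exchange than cyclohexyl. For the compounds shown here, compound 3 stays at a limit of the assay, > 50 mg/kg, and no single-place step joins it to the other members.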